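Oxolanyl to methyl exchange on the shared core: clearance notes

The compounds below may be only part of what the source reports. "The series", "measured", "known", "first", "only" and "open" are said of these compounds alone.

Measured compounds:
compound 1, `Cc1cc(C)c(CN2CCc3c(Cl)cc([C@H](CO)[C@H]4CCOC4)c(Cl)c3C2=O)c(=O)[nH]1`: 21.3 uL/min
compound 2, `CCOC(c1cc(Cl)c2c(c1Cl)C(=O)N(Cc1c(C)cc(C)[nH]c1=O)CC2)C1CS(=O)(=O)C1`: 45.7 uL/min; 124 uL/min (2 entries)

In an ADME assay on microsomes from liver (Homo sapiens) for metabolic stability, read by LC-MS, using NADPH, with stated times of 10 min and 45 min, tested at 1 uM (on this read-out higher numbers stand for fast clearance and lower numbers for slow clearance), compound 1 gives 21.3 uL/min. Among the compounds with values here, this is the only single number in the set; the other measured compound carries no single number. Compound 2 has several entries in this assay, (the several entries of compound 2 in this assay, 45.7 uL/min; 124 uL/min (2 entries)), and the spread between those entries is wide, so compound 2 gives no fixed point against which compound 1 can be placed.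

Compound 3, `Cc1cc(C)c(CN2CCc3c(Cl)cc([C@@H](C)CO)c(Cl)c3C2=O)c(=O)[nH]1`, has not yet been measured in this assay. It differs from compound 1 in one place: methyl in place of oxolan-3-yl on a saturated chain carbon bound to an aromatic carbon and a saturated chain carbon. Within the data shown here, no pair of measured compounds differs in one place, so the size of this kind of change cannot be read from a neighbouring pair, and the wide spread seen for compound 2 in this assay shows how much repeated runs can move.

The expected step from compound 1 to compound 3 in this assay is a 1.2-fold lower number from compound 1 to compound 3 (0.07 log units; within the scatter), which is taken to be no larger than the scatter of repeated runs. Compound 3 is therefore estimated at 18 uL/min in this assay, with a range from 8 uL/min to 40 uL/min.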

Compound 3, intrinsic clearance in a liver preparation (reported as CLH), per the amount of preparation that the assay uses: 12.4 uL/min
For compound 3 the middle estimate is 1.5-fold (0.16 log units) above the measured one; the measured number falls inside the stated range.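

In this assay, methyl in place of oxolan-3-yl gives a 1.7-fold lower number from compound 1 to compound 3 (0.23 log units; within the scatter), the first one-place step available in this series. On a saturated chain carbon bound to an aromatic carbon and a saturated chain carbon, the one five-membered non-aromatic ring with its single hetero atom and defined stereocentre can therefore give way to methyl with no step beyond the scatter, and the clearance of the two compounds cannot be told apart. The step should be read with caution, as repeated entries for a compound in this series can lie far apart: the several entries of compound 2 in this assay, 45.7 uL/min; 124 uL/min (2 entries)

The compounds shown leave open how an amine, a carboxylic acid or a longer chain such as n-butyl would read at this place in this assay, so the range of groups that this place accepts without a step beyond the scatter remains undefined. As far as these compounds go, a single pair also gives no general rule for this exchange, and whether methyl in place of oxolan-3-yl would give a similar step on a core other than the shared core remains open.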